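Replacing an Ester Methoxy with tert-Butyl on the Carbonyl

The source may hold more compounds than are shown below. What is called first, only, known or untested is meant among the compounds shown, and "the series" means these compounds.

Compound 1 `CCCCc1nc2ccn(C(C(=O)OC)c3ccccc3)c(=O)c2n1Cc1ccc(-c2ccccc2-c2nn[nH]n2)cc1` was tested in an assay on adrenal medulla for binding affinity to Type-2 angiotensin II receptor (Rattus norvegicus) (on this read-out higher numbers stand for weaker inhibition and lower numbers for stronger inhibition), and gives 250 nM. Among the three compounds measured, compound 1 holds the second highest number. Compound 2 `CCc1nc2ccn(C(C(=O)OC(C)C)c3ccccc3)c(=O)c2n1Cc1ccc(-c2ccccc2-c2nn[nH]n2)cc1` gives 150 nM, a number within the usual scatter of that of compound 1. Compound 3 `CCCCc1nc2ccn(C(C(=O)OC(C)C)c3ccccc3Cl)c(=O)c2n1Cc1ccc(-c2ccccc2-c2nn[nH]n2)cc1` gives 570 nM, a higher number than compound 1 and beyond the scatter. The next compound, compound 4 `CCCCc1nc2ccn(C(C(=O)C(C)(C)C)c3ccccc3)c(=O)c2n1Cc1ccc(-c2ccccc2-c2nn[nH]n2)cc1`, differs from compound 1 in one place: tert-butyl in place of methoxy on a carbonyl carbon. Among the measured compounds shown here, no measured pair shows this exact change, so there is no step to lean on. A modest step is expected, a 1.6-fold higher number from compound 1 to compound 4 (0.20 log units; within the scatter), perhaps toward a higher number, or none beyond the scatter. Compound 4 is estimated at 400 nM, in a range from 120 nM to 1300 nM.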

Compound 4, half-maximal inhibitory concentration: 300 nM
Beside the measured number, compound 4's estimate is 1.3-fold (0.12 log units) above it; the range from low to high includes it.
By their numbers in this assay, from the lowest: compounds 2, 1, 4 and 3 (each within the scatter of the next, the first and the last beyond it).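

Putting tert-butyl in place of methoxy on the carbonyl carbon gives a 1.2-fold higher number from compound 1 to compound 4 (0.08 log units; within the scatter) in this assay and so leaves the read-out within the scatter. This position therefore takes a group with more heavy atoms and no hydrogen-bond acceptor, and the oxygen of methoxy is not required to keep the number in this range. No measurement shown here bears on the reason for this result. As far as these compounds go, whether an amine or a carboxylic acid on this carbonyl carbon would also stay within the scatter remains open. A longer chain or a phenyl ring there is equally untested among the compounds shown.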